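This account rests on a few compounds, and the source may have more. Where it says the series, first, only, none or still open, it means among the compounds named here.

In a functional assay, read by spectrophotometry, with a stated time of 30 min (a lower number here means a stronger inhibitor, a higher number a weaker inhibitor), compound 1 `CC(C)(C)c1cc(/C=C/C(=O)NCCC2CCN(Cc3ccc(F)cc3F)CC2)cc(C(C)(C)C)c1O` gives 62400 nM, compound 2 `CC(C)(C)c1cc(/C=C/C(=O)NCCC2CCN(Cc3ccccc3Cl)CC2)cc(C(C)(C)C)c1O` gives 80200 nM and compound 3 `CC(C)(C)c1cc(/C=C/C(=O)NCCC2CCN(Cc3cccc([N+](=O)[O-])c3)CC2)cc(C(C)(C)C)c1O` gives 78100 nM. Compound 3 cannot be separated from the other two, as the data show a 1.3-fold higher number from compound 1 to compound 3 (0.10 log units; within the scatter) and a 1.0-fold lower number from compound 2 to compound 3 (0.01 log units; within the scatter). Compound 4 `CC(C)(C)c1cc(/C=C/C(=O)NCCC2CCN(Cc3ccc(C#N)cc3)CC2)cc(C(C)(C)C)c1O` carries 4-cyanophenyl in place of 3-nitrophenyl on a saturated chain carbon bound to an amine nitrogen in a ring. The nearest evidence is these two steps and a 1.3-fold higher number from compound 1 to compound 2 (0.11 log units; within the scatter), all swaps at that same place and none beyond the scatter. No step beyond the scatter is therefore expected in this assay. The expected step is a 1.1-fold lower number from compound 3 to compound 4 (0.04 log units; within the scatter). For compound 4 the estimated value is 72000 nM, with an expected range of 35000 nM to 135000 nM.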

Compound 4, half-maximal inhibitory concentration: 79500 nM
Beside the measured number, compound 4's estimate is 1.1-fold (0.04 log units) below it; the measured number falls inside the stated range.
By their numbers in this assay, from the lowest: compounds 1, 3, 4 and 2 (each within the scatter of the next).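

In this assay, 4-cyanophenyl at this place adds a fourth substituted phenyl group that cannot be separated from the other three (a 1.0-fold higher number from compound 3 to compound 4 (0.01 log units; within the scatter)) (a 1.0-fold lower number from compound 2 to compound 4 (0.00 log units; within the scatter)) (a 1.3-fold higher number from compound 1 to compound 4 (0.11 log units; within the scatter)). The nitrile-bearing ring therefore extends the flat picture already seen among the nitro-, chloro- and fluoro-bearing rings, with no swap at this place yet moving the number beyond the scatter. Nothing measured here accounts for this flatness. All the groups shown are substituted phenyl rings. From the compounds shown here alone, whether an amine or a carboxylic acid on that ring, or a longer chain between the ring and the amine nitrogen, would give a step beyond the scatter stays open.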